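A few compounds are considered here, and "the series" means these few. Any claim that something is new, unique, unknown or untested is made for them only; others in the source may bear on it.

Compound 2 `O=C(NCc1ccc(OCc2ccncc2)cc1)[C@@H]1CCC(=O)N1Cc1ccccc1` is known only by a limit. In an assay on HEK293 cells for inhibition of Ataxin-2 (Mus musculus), read by fluorescence and Amplex Red (a lower number here means a stronger inhibitor, a higher number a weaker inhibitor), compound 2 gives > 5000 nM, which is a limit of the assay and not a number. Compound 1 `COC(=O)c1ccc(COc2ccc(CNC(=O)[C@@H]3CCC(=O)N3Cc3ccccc3)cc2)cc1` likewise stops at a limit, giving > 5000 nM in this assay. Among the compounds with values here, the one measured step, a step that the two limits leave unreadable from compound 1 to compound 2, cannot be read, since both values sit at the limit of > 5000 nM in this assay, at which 2 of the 2 values shown sit. Compound 3 `O=C(NCc1ccc(OCc2ccc(B(O)O)cc2)cc1)[C@@H]1CCC(=O)N1Cc1ccccc1` carries a group of 9 heavy atoms (6 carbon, 1 boron, 2 oxygen; one six-membered aromatic ring of carbon only) in place of a group of 6 heavy atoms (5 carbon, 1 nitrogen; one six-membered aromatic ring with 1 hetero atom), on a saturated chain carbon bound to an oxygen on an aromatic ring. No readable step bears on this change, so compound 3 is expected to stay near the limit, with an expected step that the limit leaves unreadable from compound 2 to compound 3. Compound 3 is estimated at 8000 nM, within 3000 nM to 20000 nM.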

Compound 3, half-maximal inhibitory concentration: 35 nM
Beside the measured number, compound 3's estimate is 230-fold (2.36 log units) above it, and the stated range ends above it.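

Setting the boronic acid-bearing phenyl in place of pyridin-4-yl, on a saturated chain carbon bound to an oxygen on an aromatic ring, gives an at least 140-fold lower number from compound 2 to compound 3 (2.15 log units; beyond the scatter). With the aromatic ring kept and only the group on its aromatic carbon exchanged, there is an at least 140-fold lower number from compound 1 to compound 3 (2.15 log units; beyond the scatter), so the ring alone does not account for the change. In this assay, only compound 3 gives a number rather than a limit: the limit of > 5000 nM in this assay, at which 2 of the 3 values shown sit.

The compounds shown leave open whether a carboxylic acid or a hydroxymethyl group on that aromatic carbon would serve as the boron group does.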